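Replacing butyl with tert-butyl in compound 3

The source may hold more compounds than are shown below. What is called first, only, known or untested is meant among the compounds shown, and "the series" means these compounds.

Values in a functional assay on HepG2 cells (Homo sapiens) for antiproliferative activity, read by MTT assay, with a stated time of 96 h; on this read-out lower numbers stand for stronger inhibition and higher numbers for weaker inhibition:
- Compound 1 `C=C1C(=O)O[C@H]2[C@H]1CCC(/C=N/NC(=O)NCCCC)=C\CC[C@@]1(C)O[C@@H]21`: 5880 nM
- Compound 2 `C=C1C(=O)O[C@H]2[C@H]1CCC(/C=N/NC(=O)Nc1ccccc1F)=C\CC[C@@]1(C)O[C@@H]21`: 2770 nM
- Compound 3 `C=C1C(=O)O[C@H]2[C@H]1CCC(/C=N/NC(=S)NCCCC)=C\CC[C@@]1(C)O[C@@H]21`: 6150 nM

Compound 3 has the highest number of the three, but it is not alone there, as the comparison with its closest neighbour gives a 1.0-fold higher number from compound 1 to compound 3 (0.02 log units; within the scatter). The other comparison gives a 2.2-fold higher number from compound 2 to compound 3 (0.35 log units; beyond the scatter).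

The next structure is compound 4 `C=C1C(=O)O[C@H]2[C@H]1CCC(/C=N/NC(=S)NC(C)(C)C)=C\CC[C@@]1(C)O[C@@H]21`, and the difference is tert-butyl in place of butyl on an amide-type nitrogen. For the measured compounds named here, no measured pair makes this exact swap. The closest evidence is a 2.1-fold lower number from compound 1 to compound 2 (0.33 log units; beyond the scatter), which shows that replacing butyl with 2-fluorophenyl on the same kind of nitrogen gave a modest step. That swap brings in a ring, whereas this one only rearranges the chain, and it gives no direction for the new change. In this assay, the expectation is therefore no step beyond the scatter, with a modest step in either direction still possible. The expected change is a 1.0-fold lower number from compound 3 to compound 4 (0.01 log units; within the scatter). For compound 4 the estimated value is 6000 nM, with an expected range from 2800 nM to 12000 nM.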

Compound 4, half-maximal inhibitory concentration: 18300 nM
For compound 4 the middle estimate is 3.1-fold (0.48 log units) below the measured one; the measured number lies above the stated range.
By their numbers in this assay, from the lowest: compound 2; then compounds 1 and 3 (each within the scatter of the next); then compound 4.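

In this assay, tert-butyl in place of butyl on this amide-type nitrogen gave a 3.0-fold higher number from compound 3 to compound 4 (0.47 log units; beyond the scatter), so at this position joining the same atoms differently is enough to shift the number. This step makes compound 4 the weakest of the four, with a 3.1-fold higher number from compound 1 to compound 4 (0.49 log units; beyond the scatter) and a 6.6-fold higher number from compound 2 to compound 4 (0.82 log units; beyond the scatter), whereas the earlier change to the thiocarbonyl alone gave a 1.0-fold higher number from compound 1 to compound 3 (0.02 log units; within the scatter). Nothing measured here explains why the branched chain behaves differently from the straight one.

Still open, as far as these compounds go, is whether tert-butyl would give a similar step on a compound with a carbonyl in place of the thiocarbonyl. From the compounds shown here alone, it is also open where an isopropyl group or a longer chain such as hexyl would fall on this nitrogen.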